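Adding One Carbon to a Chain on an Inactive Core

The source may hold more compounds than are shown below. What is called first, only, known or untested is meant among the compounds shown, and "the series" means these compounds.

Compound 1 `CCCc1nc(C)c2c(C)nn(C)c(=O)n12` was tested in a functional assay for inhibition, with Homo sapiens as the target; on this read-out lower numbers stand for stronger inhibition and higher numbers for weaker inhibition. In this assay compound 1 returned only the limit of the measurement, > 48000 nM, not a number. Two further compounds were also tested. Compound 2 `C=CCn1ncc2cnc(Cc3ccccc3)n2c1=O` likewise gave only the limit, > 48000 nM. Compound 3 `CC(C)c1ncn2c(S)nncc12` also stopped at the limit, > 48000 nM. All three results sit at the limit of > 48000 nM in this assay, at which 3 of the 3 values shown sit, so no ranking among them is possible.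

Compound 4 `CCCc1nc(C)c2c(C)nn(CC)c(=O)n12` differs from compound 1 by methyl in place of hydrogen on a saturated chain carbon bound to an aromatic nitrogen, in words a methyl in place of hydrogen on a saturated chain carbon bound to an aromatic nitrogen. Going by the values given here, with every measured compound at the limit, no step of any size has been observed, and the change from compound 1 to compound 4 is expected to give a step that the limit leaves unreadable from compound 1 to compound 4, or none beyond the scatter. Compound 4 is therefore estimated at 60000 nM, within 20000 nM to 200000 nM, most likely again reported only as a limit.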

Compound 4, half-maximal inhibitory concentration: > 48000 nM
Compound 4: only a limit was reported; the forecaster's own chance of this, stated with the estimate: 85%; the middle value lies beyond the limit too.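

Compound 4, like compound 1, gave only a limit, so no step between the two can be read: the limit of > 48000 nM in this assay, at which 4 of the 4 values shown sit.

What the compounds shown leave open is whether any change to the shared core gives a measurable value in this assay.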